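Swapping a fluorinated tail for a small carbon ring

The compounds below may be only part of what the source reports. "The series", "measured", "known", "first", "only" and "open" are said of these compounds alone.

Of the compounds shown here, two built on a shared core have been measured so far. Compound 1, `COc1c(F)cccc1C1CCN(c2ccn3c(CC(F)(F)F)nnc3c2C#N)CC1`, gives 31 nM in a functional assay on CHO cells for agonist activity at metabotropic glutamate receptor 2 (Homo sapiens), read by scintillation counting and GTPgammaS binding, with a stated time of 30 min; a lower number here means that less compound is needed, a higher number that more compound is needed for the effect. Compound 2, `COc1ccc(F)cc1C1CCN(c2ccn3c(CC(F)(F)F)nnc3c2Cl)CC1`, gives 10.5 nM in this assay, which is the lowest of the two numbers; compound 1 stands beyond the usual scatter above it. Compound 3, `COc1ccc(F)cc1C1CCN(c2ccn3c(CC4CC4)nnc3c2Cl)CC1`, has not yet been measured. It differs from compound 2 in one place: cyclopropyl in place of trifluoromethyl on a saturated chain carbon bound to an aromatic carbon. Among the compounds with values here, no pair of measured compounds shows this change, so nothing here tells how it plays out. With no guide to lean on, the step from compound 2 to compound 3 is expected to be modest, most likely toward a somewhat higher number, though a result within the scatter would not surprise: a 2.4-fold higher number from compound 2 to compound 3 (0.38 log units; beyond the scatter). Compound 3 is therefore estimated at 25 nM, with a range from 8 nM to 80 nM.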

Compound 3, half-maximal effective concentration: 8.2 nM
Compound 3: the middle estimate sits 3.0-fold (0.48 log units) above what was measured, within the range that was stated.
By their numbers in this assay, from the lowest: compounds 3 and 2 (each within the scatter of the next); then compound 1.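

In this assay the step is a 1.3-fold lower number from compound 2 to compound 3 (0.11 log units; within the scatter), so at this place, on a saturated chain carbon bound to an aromatic carbon, cyclopropyl can replace trifluoromethyl with no difference that stands out from repeat measurements. For this pair, then, the fluorine atoms are not needed to keep this level of activity, and a small all-carbon ring serves as well. Nothing measured here bears on the reason for this result.

One pair cannot show how much variety this place accepts: a longer chain such as butyl, a larger ring such as cyclohexyl, or an amine could behave quite differently. Going by these compounds, whether the same swap would also leave the number for compound 1 within the scatter remains open.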